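Thiosemicarbazone series: Vero cytotoxicity, nitro to methyl step

The source may report more compounds than this note shows. Statements on the series, on what has been measured and on what is new or still open speak of the compounds shown alone.

Measured compounds:
Compound 1 `S=C(N/N=C\c1ccc(Cl)cc1)N(Cc1ccccc1)Cc1ccccc1`; in an ADME assay on Vero cells (Chlorocebus sabaeus) for cytotoxicity, read by MTT assay, with a stated time of 72 h (a higher number here means that more compound is tolerated, a lower number that less compound is tolerated), compound 1 gives 159000 nM.
Compound 2 `CC/C(C)=N\NC(=S)N(Cc1ccccc1)Cc1ccccc1`; in this assay the entry for compound 2 reads "not determined" (no result reported), so no number was reported for it.
Compound 3 `C=CCN(CC=C)C(=S)N/N=C\c1ccccc1[N+](=O)[O-]`; in this assay compound 3 gives 205000 nM.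

Compound 3 and compound 1 lie within the usual scatter of each other, so nothing separates them on this assay; compound 2 contributes no number.

Compound 4 `C=CCN(CC=C)C(=S)N/N=C\c1ccccc1C` is the unmeasured analogue of compound 3. The change is methyl in place of nitro on an aromatic carbon. Within the data shown here, no comparable step between measured compounds exists, so the expected step from compound 3 to compound 4 is a 1.0-fold lower number from compound 3 to compound 4 (0.01 log units; within the scatter), none beyond the scatter in either direction. Compound 4 is accordingly expected to give 200000 nM in this assay, with an estimated range from 80000 nM to 500000 nM.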

Compound 4, half-maximal cytotoxic concentration: > 228000 nM
Compound 4: no number, only a limit; the forecaster's own chance of this, stated with the estimate: 25%; middle value at least 1.1-fold (0.05 log units) away from the limit.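

In this assay compound 4 gives only a limit and not a number, > 228000 nM. The series now holds one step at this position, an at least 1.1-fold higher number from compound 3 to compound 4 (0.04 log units; that floor lies within the scatter), and it shows that the number does not fall with methyl in place of nitro on an aromatic carbon, ortho to a large group. For compound 4 that step has only a floor: the limit of > 228000 nM in this assay, at which 1 of the 4 values shown sits.

Going by these compounds, whether the true step lies beyond the scatter stays open. Also open, on these data alone, is how an amine or a carboxylic acid on this aromatic carbon would read in this assay.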